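The source may hold more compounds than are shown below. What is called first, only, known or untested is meant among the compounds shown, and "the series" means these compounds.

In a functional assay on MCF7 cells (Homo sapiens) for cytotoxicity, read by MTT assay, with a stated time of 3 days (a lower number here means a stronger inhibitor, a higher number a weaker inhibitor), compound 1 `COc1ccc(-c2cccc(O)c2)cc1` gives 48 ug/mL and compound 3 `COc1ccc(-c2cccc(O)c2)c(OC)c1` gives 50.2 ug/mL, so the two stand level. For compound 2 `COc1ccc(-c2ccccc2)c(OC)c1` the reading is a limit, > 100 ug/mL. The methoxy step is a 1.0-fold higher number from compound 1 to compound 3 (0.02 log units; within the scatter), and the hydroxy step is an at least 1.9-fold lower number from compound 2 to compound 3 (0.29 log units; that floor lies within the scatter). Compound 4 `COc1ccc(-c2cccc(N)c2)c(OC)c1` carries amino in place of hydroxy on an aromatic carbon, with amino in place of hydroxy on an aromatic carbon. Among the compounds with values here, no measured step covers this exchange directly. The hydroxy step bears on it most closely, but it starts from a limit and its floor stays within the scatter, so no shift beyond the scatter is expected. The starting point in this assay is compound 3 at 50.2 ug/mL. The expected step is a 1.1-fold lower number from compound 3 to compound 4 (0.05 log units; within the scatter). For compound 4 the estimate is 45 ug/mL, with an expected range from 18 ug/mL to 100 ug/mL.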

Compound 4, half-maximal inhibitory concentration: > 100 ug/mL
Compound 4: no number, only a limit; the forecaster's own chance of this, stated with the estimate: 20%; middle value at least 2.2-fold (0.34 log units) away from the limit.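

In this assay, amino in place of hydroxy at this place, meta to a large group, gives an at least 1.9-fold higher number from compound 3 to compound 4 (0.29 log units; that floor lies within the scatter), so the change yields a limit rather than a number, but no shift beyond the scatter is established. At this position, hydroxy in compound 3 is the only one of the three groups shown to give a number, while amino in compound 4 and hydrogen in compound 2 both end at a limit: the limit of > 100 ug/mL in this assay, at which 2 of the 4 values shown sit. The step between those two cannot be read.

As far as these compounds go, how far compound 4 lies past its limit stays open. So does whether a methylamino group or a carboxylic acid at this place would give a number.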